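The source may hold more compounds than are shown below. What is called first, only, known or untested is meant among the compounds shown, and "the series" means these compounds.

Measured in an ADME assay on S9 fraction from liver (Rattus norvegicus) for metabolic stability, with a stated time of 1 h; on this read-out lower numbers stand for a less stable compound and higher numbers for a more stable compound:
- compound 1 `N#Cc1cnc(NCc2cnccc2C(F)(F)F)cc1NC[C@H]1C[C@H](O)C1`: 61%
- compound 2 `CO[C@H]1CC[C@@H](CNc2cc(NCc3cnccc3C(F)(F)F)ncc2C#N)CC1`: 2%

Compound 2 is the lower of the two, and compound 3 `N#Cc1cnc(NCc2cnccc2C(F)(F)F)cc1NCCC1CCOCC1` departs from it by (oxan-4-yl)methyl in place of 4-methoxycyclohexyl on a saturated chain carbon bound to a nitrogen on an aromatic ring. Within the data shown here, only one measured step bears on this change: a number 59 percentage points lower from compound 1 to compound 2 (beyond the scatter), a large step beyond the scatter at the same place. Among the measured compounds shown here, no measured compound carries (oxan-4-yl)methyl, so this guide is loose. Compound 2, at 2%, has little room to fall, so a rise beyond the scatter, smaller than that step, is expected. The estimated change is a number 23 percentage points higher from compound 2 to compound 3 (beyond the scatter). Compound 3 is estimated at 25%, with an expected range of 6% to 55%.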

Compound 3, percent of the compound remaining: 0%
For compound 3 the middle estimate is 25 percentage points above the measured one, outside the stated range (below it).
By their numbers in this assay, from the lowest: compounds 3 and 2 (each within the scatter of the next); then compound 1.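

In this assay the change reads a number 2 percentage points lower from compound 2 to compound 3 (within the scatter) so (oxan-4-yl)methyl, with its six-membered ring with 1 hetero atom, stands level with 4-methoxycyclohexyl, whose six-membered ring is of carbon only. The second step reads a number 61 percentage points lower from compound 1 to compound 3 (beyond the scatter) so both six-membered ring groups now sit far from 3-hydroxycyclobutyl at this place. Nothing given here explains these numbers. From the compounds shown here alone, whether the gap follows the hydroxyl or the small ring stays open. A 4-hydroxycyclohexyl or a 3-methoxycyclobutyl group on the same chain carbon would separate the two.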